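Indole nitrogen acylation in a cysteinyl leukotriene receptor series

This account rests on a few compounds, and the source may have more. Where it says the series, first, only, none or still open, it means among the compounds named here.

Two compounds sharing one core were measured in an assay on isolated protein for binding affinity to cysteinyl leukotriene receptor 1 (Cavia porcellus); a lower number here means a stronger inhibitor, a higher number a weaker inhibitor. Compound 1 `COc1cc(C(=O)NS(=O)(=O)c2ccccc2C)ccc1Cc1c[nH]c2ccc(NC(=O)OC3CCCC3)cc12` gives 1 nM in this assay, the lower of the two numbers recorded so far. Compound 2 `COc1cc(C(=O)NS(=O)(=O)c2ccccc2C)ccc1Cc1cn(C(=O)N(c2ccccc2)c2ccccc2)c2ccc(NC(=O)OC3CCCC3)cc12` gives 2 nM in this assay, a number that lies within the usual scatter of that of compound 1, so the two are treated as equal. Compound 3 `COc1cc(C(=O)NS(=O)(=O)c2ccccc2C)ccc1Cc1cn(C(=O)N2CCOCC2)c2ccc(NC(=O)OC3CCCC3)cc12` has not yet been measured. Compared with compound 1 it carries (morpholin-4-yl)carbonyl in place of hydrogen on an aromatic nitrogen. Nothing in the measured pair shows any step beyond the scatter, and the change to compound 3 touches the same aromatic nitrogen at which compound 2 already tolerated a large group without measurable loss. The expectation is therefore that the step from compound 1 to compound 3 in this assay is small, a 2.0-fold higher number from compound 1 to compound 3 (0.30 log units; within the scatter), with no direction beyond the scatter. Compound 3 is expected to give about 2 nM, estimated between 0.8 nM and 6 nM.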

Compound 3, half-maximal inhibitory concentration: 0.4 nM
For compound 3 the middle estimate is 5.0-fold (0.70 log units) above the measured one; measured number outside the range, below it.
By their numbers in this assay, from the lowest: compound 3; then compounds 1 and 2 (each within the scatter of the next).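

In this assay, going by these compounds alone, (morpholin-4-yl)carbonyl in place of hydrogen on the aromatic nitrogen gives a 2.5-fold lower number from compound 1 to compound 3 (0.40 log units; beyond the scatter), the first step at this position that lies beyond the scatter. The position therefore does more than accept a substituent without measurable loss, since here the number moves, though only modestly, towards a stronger inhibitor. The hydrogen on this nitrogen is also shown not to be required for a low number in this assay, but nothing available here explains the step.

Still open, on these data alone, is which part of the entering group carries the step. A piperidin-1-ylcarbonyl group on the same nitrogen would test the ring oxygen, and a plain acetyl group would show whether the carbonyl without any ring gives a similar number.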